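Swapping a Fluorophenyl for Trimethoxyphenyl: Expected Growth Inhibition

This account rests on a few compounds, and the source may have more. Where it says the series, first, only, none or still open, it means among the compounds named here.

Measured compounds in a functional assay on MCF7 cells (Homo sapiens) for antiproliferative activity, read by sulforhodamine B assay, with a stated time of 48 h; a lower number here means a stronger inhibitor of growth, a higher number a weaker inhibitor of growth:
- Compound 1, `COc1ccc(Cn2cc(CNC(=O)c3cn(-c4ccccc4)nc3-c3ccccc3)nn2)cc1OC`, gives 12600 nM.
- Compound 2, `O=C(NCc1cn(Cc2ccc(F)cc2)nn1)c1cn(-c2ccccc2)nc1-c1ccc(F)cc1`, gives 55300 nM.
- Compound 3, `COc1cc(Cn2cc(CNC(=O)c3cn(-c4ccccc4)nc3-c3ccc(F)cc3)nn2)cc(OC)c1`, gives 2500 nM.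

Compound 2 stands highest of the three numbers, so it is the weakest growth inhibitor here; compound 1 sits closer to it and compound 3 furthest away. Compound 4, `COc1cc(Cn2cc(CNC(=O)c3cn(-c4ccccc4)nc3-c3ccc(F)cc3)nn2)cc(OC)c1OC`, differs from compound 2 by one change: 3,4,5-trimethoxyphenyl in place of 4-fluorophenyl on a saturated chain carbon bound to an aromatic nitrogen. Within the data shown here, the closest guide is the single step that swaps the same fluorophenyl for a dimethoxyphenyl at the same place, a 22-fold lower number from compound 2 to compound 3 (1.34 log units; beyond the scatter). The change to compound 4 adds a third methoxy group to that same kind of ring, so a step of similar direction and size is expected in this assay, namely a 31-fold lower number from compound 2 to compound 4 (1.49 log units; beyond the scatter). Compound 4 is therefore estimated at 1800 nM, with a plausible range from 450 nM to 7000 nM.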

Compound 4, concentration for 50% growth inhibition: 4300 nM
For compound 4 the middle estimate is 2.4-fold (0.38 log units) below the measured one; the range from low to high includes it.
By their numbers in this assay, from the lowest: compounds 3 and 4 (each within the scatter of the next); then compound 1; then compound 2.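

In this assay the 3,4,5-trimethoxyphenyl group on a saturated chain carbon bound to an aromatic nitrogen also outperforms 4-fluorophenyl, with a 13-fold lower number from compound 2 to compound 4 (1.11 log units; beyond the scatter) as the step, so a second methoxy-bearing ring gives a large gain at this position. Adding a methoxy to the ring gives a 1.7-fold higher number from compound 3 to compound 4 (0.24 log units; within the scatter) as the step, so these two methoxy-bearing rings cannot be told apart here. Nothing available explains why these rings outperform 4-fluorophenyl.

Going by these compounds, whether an amine or a carboxylic acid on this ring would match the methoxy groups stays open.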